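Pyridin-2-yl Replaces Cyclopentyl on an Amide Nitrogen

The source may hold more compounds than are shown below. What is called first, only, known or untested is meant among the compounds shown, and "the series" means these compounds.

Compound 1 `C#CCn1cc(C(=O)NC(CC(=O)Nc2ccccc2)c2ccccc2)c(=O)c2cccnc21` — 7200 nM
Compound 2 `C#CCn1cc(C(=O)NC(CC(=O)NC2CCCC2)c2ccccc2)c(=O)c2cc(F)c(Cl)nc21` — > 10000 nM

In a functional assay on DU-145 cells (Homo sapiens) for cytotoxicity, read by MTT assay, with a stated time of 72 h (a lower number here means a stronger inhibitor, a higher number a weaker inhibitor), compound 1 gives 7200 nM. Compound 2 reaches only a limit of this assay, > 10000 nM, and so stands at the limit of > 10000 nM in this assay, at which 1 of the 2 values shown sits. Compound 3 `C#CCn1cc(C(=O)NC(CC(=O)Nc2ccccn2)c2ccccc2)c(=O)c2cc(F)c(Cl)nc21` has not been measured; it differs from compound 2 by pyridin-2-yl in place of cyclopentyl on an amide-type nitrogen. Among the measured compounds shown here, since compound 2 offers only a limit, no measured step tells how far this change carries, and the step is expected to be modest, towards stronger inhibition, as an at least 1.2-fold lower number from compound 2 to compound 3 (0.09 log units; that floor lies within the scatter). Compound 3 is expected to give 8000 nM, between 3000 nM and 20000 nM.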

Compound 3, half-maximal inhibitory concentration: 2100 nM
Estimate against measurement, compound 3: 3.8-fold (0.58 log units) above, and the stated range ends above it.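

On the amide-type nitrogen, pyridin-2-yl in place of cyclopentyl gives, in this assay, an at least 4.7-fold lower number from compound 2 to compound 3 (0.67 log units; beyond the scatter). Among the compounds shown here, this is the first sign that the group on this nitrogen can move cytotoxicity beyond the scatter on this shared core. The true size of the step stays unknown, as compound 2 stands at a limit of the assay: the limit of > 10000 nM in this assay, at which 1 of the 3 values shown sits.

The compounds shown leave open how pyridin-3-yl or cyclohexyl on this nitrogen would read. It therefore remains unclear whether the step follows the aromatic ring or its ring nitrogen.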